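The compounds below may be only part of what the source reports. "The series", "measured", "known", "first", "only" and "open" are said of these compounds alone.

Measured compounds:
compound 1, `O=C1/C(=C/c2ccccc2F)CN(C(=S)SCc2cn(Cc3ccc(F)cc3)nn2)C/C1=C\c1ccccc1F`, with 51300 nM in an ADME assay on HEK293 cells (Homo sapiens) for cytotoxicity, read by MTT assay, with a stated time of 24 h; on this read-out higher numbers stand for weaker inhibition and lower numbers for stronger inhibition
compound 2, `COc1ccc(/C=C2\CN(C(=S)SCc3cn(Cc4ccccc4Cl)nn3)C/C(=C\c3ccc(OC)cc3)C2=O)cc1`, with "not determined" (no result reported) in this assay

Among the measured compounds shown here, compound 1 is the only compound with a number in this assay, where compound 1 gives 51300 nM. Compound 2 stands nowhere on these numbers: no result for it in this assay is available, so its position can only be inferred from the shared core it has with compound 1.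

Compound 3, `COc1ccc(/C=C2\CN(C(=S)SCc3cn(Cc4cccc(Cl)c4)nn3)C/C(=C\c3ccc(OC)cc3)C2=O)cc1`, differs from compound 2 as follows: 3-chlorophenyl in place of 2-chlorophenyl on a saturated chain carbon bound to an aromatic nitrogen. The two have the same atoms joined differently. For the measured compounds named here, with no measured step to lean on, the expectation for the move from compound 2 to compound 3 is a change in this assay of no size beyond the scatter, in no set direction. Taking compound 1 as the only anchor, compound 3 is estimated at 35000 nM, within a range from 6000 nM to 120000 nM.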

Compound 3, half-maximal inhibitory concentration: > 100000 nM
Compound 3 gave a limit, no number; the forecaster's own chance of this, stated with the estimate: 30%; at least 2.8-fold (0.45 log units) between middle value and limit.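

No step can be read between compound 2 and compound 3: compound 2 has no number in this assay, and compound 3 gives > 100000 nM, which is a limit and not a number. On these data alone, whether 3-chlorophenyl in place of 2-chlorophenyl shifts cytotoxicity at all remains open.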